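A few compounds are considered here, and "the series" means these few. Any claim that something is new, unique, unknown or untested is made for them only; others in the source may bear on it.

For the measured compounds named here, in a functional assay for inhibition, with Homo sapiens as the target (on this read-out higher numbers stand for weaker inhibition and lower numbers for stronger inhibition), compound 1 `Cc1cccc(Nc2nccc(-c3ccccn3)n2)c1` gives 700 nM and holds the higher of the two numbers so far. Compound 2 `Cc1cccc(Nc2nccc(-c3cccs3)n2)c1` gives 300 nM with thiophen-2-yl in place of pyridin-2-yl on an aromatic carbon. Compound 3 `NS(=O)(=O)c1cccc(Nc2nccc(-c3ccccn3)n2)c1` instead carries sulfamoyl in place of methyl on an aromatic carbon as sulfamoyl in place of methyl on an aromatic carbon, meta to a large group. Going by the values given here, the only measured step, a 2.3-fold lower number from compound 1 to compound 2 (0.37 log units; beyond the scatter), is modest and lies at another place, so it hints at size but not at direction. The estimated step is a 1.4-fold lower number from compound 1 to compound 3 (0.15 log units; within the scatter) and none beyond the scatter is expected. For compound 3 the estimated value is 500 nM with 120 nM to 2000 nM as the expected range.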

Compound 3, half-maximal inhibitory concentration: 500 nM
The estimate for compound 3 equals the measured number at the digits printed, within the range that was stated.
By their numbers in this assay, from the lowest: compounds 2, 3 and 1 (each within the scatter of the next, the first and the last beyond it).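

The step of a 1.4-fold lower number from compound 1 to compound 3 (0.15 log units; within the scatter) comes from replacing methyl with sulfamoyl, on a ring carbon meta to a large group. Sulfamoyl has 4 heavy atoms against 1 for methyl and adds a hydrogen-bond donor and hydrogen-bond acceptors, yet compound 1 and compound 3 cannot be told apart in this assay, so this position accepts this much larger group without a clear change in the read-out. No available evidence explains this result. As far as these compounds go, it remains open whether an amine or a carboxylic acid at this place would also stay within the scatter, and whether sulfamoyl would do so with thiophen-2-yl in place of pyridin-2-yl.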